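Primary amide to difluorobenzamide: lipophilicity expected to rise

The source may report more compounds than this note shows. Statements on the series, on what has been measured and on what is new or still open speak of the compounds shown alone.

Measured compounds:
compound 1 `Cc1cc(C(N)=O)nn1Cc1cc(Cl)ccc1OCc1ccccc1` — 3.7
compound 2 `Cc1cc(NC(=O)C2CCCC2)nn1Cc1cc(Cl)ccc1OCc1ccccc1` — 3.5
compound 3 `Cc1cc(NC(=O)C2CCOCC2)nn1Cc1cc(Cl)ccc1OCc1ccccc1` — > 3.7

In a physicochemical assay for lipophilicity, at pH 7.4 (a lower number here means a more polar compound, a higher number a more lipophilic compound), compound 1 gives 3.7. Among the two plain numbers compound 1 stands highest, with compound 2 nearest at a number 0.20 log units lower from compound 1 to compound 2 (within the scatter). Compound 3 reaches only a limit of the method, > 3.7, so its number is not known. The step of a number no lower from compound 1 to compound 3 (the limit leaves the size open) therefore has no readable size, and likewise a number at least 0.20 log units higher from compound 2 to compound 3 (that floor lies within the scatter). One of the three values sits at the limit of > 3.7 in this assay, at which 1 of the 3 values shown sits.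

Compound 4 `Cc1cc(NC(=O)c2c(F)cccc2F)nn1Cc1cc(Cl)ccc1OCc1ccccc1` differs from compound 1 by ((2,6-difluorophenyl)carbonyl)amino in place of carbamoyl on an aromatic carbon. The measured steps that bear on this change are those from the carbamoyl of compound 1 to the larger amides of compound 2 and compound 3; the first lay within the scatter, the second ran into the limit. For compound 4 a step upward in this assay is expected, and the estimate is a number 0.60 log units higher from compound 1 to compound 4 (beyond the scatter), with the chance that only a limit is reported. Compound 4 is estimated at 4.3, between 3.7 and 4.9.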

Compound 4, distribution coefficient: > 3.7
Compound 4: a limit, no number; the forecaster's own chance of this, stated with the estimate: 60%; the middle value is on the limit's open side.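

In this assay, compound 4 gives only a limit, > 3.7, and no number. With 2,6-difluorophenyl in place of cyclopentyl on the carbonyl carbon, the result is a number at least 0.20 log units higher from compound 2 to compound 4 (that floor lies within the scatter), a floor rather than a size. With ((2,6-difluorophenyl)carbonyl)amino in place of carbamoyl on the aromatic carbon, the result is a number no lower from compound 1 to compound 4 (the limit leaves the size open), and neither the size of that step nor the step from compound 3 to compound 4 can be read. At this position on the aromatic carbon, a second of the larger amides has now left the measurable range: the limit of > 3.7 in this assay, at which 2 of the 4 values shown sit.

On these data alone, how far compound 3 and compound 4 lie past that limit stays unknown, so the oxan-4-yl and 2,6-difluorophenyl amides cannot be ranked against each other or against the carbamoyl of compound 1. Also open, as far as these compounds go, is what a carboxylic acid or an amine on this same aromatic carbon would give in this assay.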